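From Ethoxycarbonyl to 4-Methoxyphenyl: Compound 3 Foreseen

The compounds below may be only part of what the source reports. "The series", "measured", "known", "first", "only" and "open" are said of these compounds alone.

Measured so far in a functional assay on PC-12 cells (Rattus norvegicus) for cytotoxicity, read by MTT assay, with stated times of 3 h and 2 h, tested at 20 uM; a lower number here means a weaker effect, a higher number a stronger effect of the compound at the concentration tested:
- compound 1 `O=C(CCCCC1CCSS1)NCc1cn(CCCCOc2ccc3ccc(=O)oc3c2)nn1` gives 69.8%
- compound 2 `CCOC(=O)c1cc2ccc(OCCCCCn3cc(CNC(=O)CCCCC4CCSS4)nn3)cc2oc1=O` gives 39.5%

Of the compounds shown here, two have been measured. Compound 1 reaches 69.8% in this assay, and compound 2 gives 39.5%, the lower of the two numbers, with the gap to compound 1 lying beyond the usual scatter. Where compound 2 stands is therefore clear: it is the weaker of the pair on the numbers shown so far.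

Compound 3 `COc1ccc(-c2cc3ccc(OCCCCCn4cc(CNC(=O)CCCCC5CCSS5)nn4)cc3oc2=O)cc1` is the next step and has not yet been measured in this assay. It differs from compound 2 in one place: 4-methoxyphenyl in place of ethoxycarbonyl on an aromatic carbon. Within the data shown here, no pair of measured compounds shares this change, so there is no measured step to lean on, and any expectation rests on the two values alone.

Given that, compound 3 is expected to move toward the middle of the range between compound 2 and compound 1, a step of a number 10.5 percentage points higher from compound 2 to compound 3 (beyond the scatter) that may or may not exceed the scatter. The estimate for compound 3 in this assay is 50%, within 25% to 75%.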

Compound 3, a percentage reported as activity, at one concentration (the size of the read-out at that concentration, not a potency): 49%
Compound 3: the middle estimate sits 1 percentage points above what was measured; the measured number falls inside the stated range.
By their numbers in this assay, from the lowest: compounds 2 and 3 (each within the scatter of the next); then compound 1.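

In this assay, among these compounds, placing 4-methoxyphenyl instead of ethoxycarbonyl on the aromatic carbon two atoms from the ring oxygen gives a number 9.5 percentage points higher from compound 2 to compound 3 (within the scatter), the first measured step at this position. A group of 5 heavy atoms without a ring gives way to one of 8 heavy atoms with a six-membered aromatic ring of carbon only, yet the two read-outs at the tested concentration cannot be told apart, so this position accepts this particular exchange without a clear shift in the number. Nothing measured alongside these numbers accounts for the small size of this step.

Compound 1 carries neither group and also differs from compound 2 in the chain, so the part each of these differences plays in its number remains unresolved. Going by these compounds, it also remains open how a carboxylic acid, an amine or a simple methyl at this position would read, and whether a longer chain on the 4-methoxyphenyl compound would alter the result.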